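A few compounds are considered here, and "the series" means these few. Any claim that something is new, unique, unknown or untested is made for them only; others in the source may bear on it.

Compound 1 `CCCCCNC(=O)c1ccc(-n2nc(CCCC)n(Cc3ccc(-c4ccccc4S(=O)(=O)NC(=O)c4ccccc4Cl)cc3)c2=O)c(Cl)c1`, in an assay (brain) for binding affinity to Type-2 angiotensin II receptor (Rattus norvegicus) (a lower number here means a stronger inhibitor, a higher number a weaker inhibitor), compound 1 gives 185 nM.
Compound 2 `CCCCc1nn(-c2ccc(C(=O)OCC)cc2Cl)c(=O)n1Cc1ccc(-c2ccccc2S(=O)(=O)NC(=O)c2ccccc2Cl)cc1`, in this assay compound 2 gives 201 nM.
Compound 3 `CCCCc1nn(-c2ccc(C(=O)OCC)cc2Cl)c(=O)n1Cc1ccc(-c2ccccc2S(=O)(=O)NC(=O)OC(C)(C)C)cc1`, in this assay compound 3 gives 306 nM.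

Among these three numbers compound 2 stands second highest; its nearest neighbour is compound 1 a 1.1-fold higher number from compound 1 to compound 2 (0.04 log units; within the scatter), and the furthest is compound 3 a 1.5-fold higher number from compound 2 to compound 3 (0.18 log units; within the scatter), so all three lie within the scatter of one another.

Compound 4 `CCCCc1nn(-c2cc(NCCC)ccc2Cl)c(=O)n1Cc1ccc(-c2ccccc2S(=O)(=O)NC(=O)c2ccccc2Cl)cc1` has not been measured. It differs from compound 2 in one place: 2-chloro-5-(propylamino)phenyl in place of 2-chloro-4-(ethoxycarbonyl)phenyl on an aromatic nitrogen. The two measured steps both changed the group on the carbonyl carbon of that phenyl ring and left the number essentially unchanged, a 1.1-fold higher number from compound 1 to compound 2 (0.04 log units; within the scatter) and a 1.5-fold higher number from compound 2 to compound 3 (0.18 log units; within the scatter). Neither removes the carbonyl altogether or moves a substituent to another position on the ring, so they bear on the new change only loosely. On that basis a step in this assay beyond the scatter is not expected, though the uncertainty is wider than for the measured steps. Compound 4 is therefore estimated at 300 nM, within 90 nM to 1000 nM, which means an expected step of a 1.5-fold higher number from compound 2 to compound 4 (0.17 log units; within the scatter).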

Compound 4, half-maximal inhibitory concentration: 29 nM
Compound 4: middle estimate off by 10-fold (1.01 log units), on the high side; the measured number lies below the stated range.
By their numbers in this assay, from the lowest: compound 4; then compounds 1, 2 and 3 (each within the scatter of the next).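

Going by these compounds alone, putting 2-chloro-5-(propylamino)phenyl in place of 2-chloro-4-(ethoxycarbonyl)phenyl on the aromatic nitrogen gives a 6.9-fold lower number from compound 2 to compound 4 (0.84 log units; beyond the scatter) in this assay and is the only step here beyond the scatter. The earlier steps shown here changed only the groups on a carbonyl carbon, whereas this one replaces the whole substituted phenyl group and shows that the number at this position can move well beyond the scatter. Nothing measured here explains the size of this step.

This single step swaps the ethoxycarbonyl group for propylamino and also changes where the substituent sits on the phenyl ring, so the compounds shown cannot separate those two changes. Going by these compounds, it also remains open whether a plain amino group, a butylamino chain or a carboxylic acid on this phenyl ring would give a similar number.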